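The source may report more compounds than this note shows. Statements on the series, on what has been measured and on what is new or still open speak of the compounds shown alone.

Of the compounds shown here, three with a shared core have been tested in a functional assay on Huh7.5.1 cells (Homo sapiens) for cytotoxicity, read by MTT assay, with a stated time of 72 h; a higher number here means that more compound is tolerated, a lower number that less compound is tolerated: compound 1 `C=c1[nH]c(=O)/c(=C/c2c[nH]c3ccccc23)[nH]c1=O`, compound 2 `C=c1[nH]c(=O)/c(=C/c2ccoc2)[nH]c1=O` and compound 3 `C=c1[nH]c(=O)/c(=C/c2ccc(C)cc2)[nH]c1=O`. Compound 1 gives > 20000 nM, which is a limit of the assay and not a number. Compound 2 gives > 20000 nM, again a limit. Compound 3 gives > 20000 nM, also a limit, so it has no exact position on the scale. The whole record so far comes down to the limit of > 20000 nM in this assay, at which 3 of the 3 values shown sit.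

Compound 4 `C=c1[nH]c(=O)/c(=C/c2ccc(N(C)C)cc2)[nH]c1=O` has not yet been measured. It differs from compound 3 in one place, with dimethylamino in place of methyl on an aromatic carbon, para to a large group (dimethylamino in place of methyl on an aromatic carbon). For the measured compounds named here, no step between measured compounds is available to size this change, so the expectation rests on the three limits alone. In this assay no step beyond the usual scatter is expected, and no direction is favoured, though a report of a limit again seems the likeliest outcome. The expected change, a step that the limit leaves unreadable from compound 3 to compound 4, is therefore only a rough estimate. Compound 4 is estimated at 30000 nM, with an expected range from 12000 nM to 80000 nM.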

Compound 4, half-maximal cytotoxic concentration: > 20000 nM
Compound 4: only a limit was reported; the forecaster's own chance of this, stated with the estimate: 75%; the middle value is on the limit's open side.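

In this assay compound 4 gives > 20000 nM, which is a limit and not a number. For the compounds shown here, compound 3 is likewise reported only as a limit, so no step between compound 3 and compound 4 can be read. The compounds shown leave open at what concentration any of them becomes cytotoxic, as the record rests on one limit: the limit of > 20000 nM in this assay, at which 4 of the 4 values shown sit.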